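The source may report more compounds than this note shows. Statements on the series, on what has been measured and on what is new or still open speak of the compounds shown alone.

Three thiourea amides built on one shared core have been tested in an ADME assay on Huh-7 cells (Homo sapiens) for cytotoxicity; a lower number here means that less compound is tolerated, a higher number that more compound is tolerated. Compound 1 `N#Cc1cccc(C(=O)NC(=S)N2CCc3c(OCCCCCOc4ccc(Cl)cc4)cccc32)c1` gives 9750 nM. Compound 2 `O=C(NC(=S)N1CCc2c(OCCCCCOc3ccc(Cl)cc3)cccc21)c1ccc(Cl)cc1` gives 21700 nM. Compound 3 `O=C(NC(=S)N1CCc2c(OCCCCCOc3ccc(Cl)cc3)cccc21)c1ccc(C(F)(F)F)cc1` gives 32700 nM, the top of the three numbers, though it is separated from compound 2 only by a 1.5-fold higher number from compound 2 to compound 3 (0.18 log units; within the scatter), and from compound 1 by a 3.4-fold higher number from compound 1 to compound 3 (0.53 log units; beyond the scatter).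

Compound 4 `COc1ccc(C(=O)NC(=S)N2CCc3c(OCCCCCOc4ccc(Cl)cc4)cccc32)cc1` differs from compound 3 by methoxy in place of trifluoromethyl on an aromatic carbon. The measured steps that bear on this change are those that swap the group on the benzoyl ring: a 1.5-fold higher number from compound 2 to compound 3 (0.18 log units; within the scatter) stayed within the scatter, while a 2.2-fold higher number from compound 1 to compound 2 (0.35 log units; beyond the scatter) and a 3.4-fold higher number from compound 1 to compound 3 (0.53 log units; beyond the scatter) were modest. Exchanging one para group for another has therefore moved this assay little, and nothing among the three compounds points to a large shift in either direction for a methoxy.

The expectation is accordingly a small step, at most modest and more likely downward toward the numbers of compound 2 and compound 1, as a 1.6-fold lower number from compound 3 to compound 4 (0.21 log units; within the scatter). Compound 4 is thus estimated at 20000 nM, with a range from 8000 nM to 50000 nM in this assay.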

Compound 4, half-maximal cytotoxic concentration: 34400 nM
Compound 4: middle estimate off by 1.7-fold (0.24 log units), on the low side; the measured number falls inside the stated range.
By their numbers in this assay, from the lowest: compound 1; then compounds 2, 3 and 4 (each within the scatter of the next).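

In this assay the exchange of trifluoromethyl for methoxy, which puts an oxygen in place of fluorine on an aromatic carbon para to a large group, produces no readable change, with a 1.1-fold higher number from compound 3 to compound 4 (0.02 log units; within the scatter) as the whole of the step. Methoxy in place of chloro at the same position reads the same way, with a 1.6-fold higher number from compound 2 to compound 4 (0.20 log units; within the scatter) also inside the scatter, so that compounds 2, 3 and 4 now form a set of three different groups at this position that this assay does not tell apart. Compound 1 alone stands apart from this set, and the new comparison, a 3.5-fold higher number from compound 1 to compound 4 (0.55 log units; beyond the scatter), repeats that gap, though nothing available offers a reason for the gap or for the sameness of the other three.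

Compound 1 differs from the others in both the group and its place on the ring, so these compounds cannot show whether its lower number goes with the nitrile or with its position. Also open is whether the flat reading at this position would hold for an amine, a carboxylic acid or a longer chain there, since the groups shown are only chloro, trifluoromethyl and methoxy.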